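A few compounds are considered here, and "the series" means these few. Any claim that something is new, unique, unknown or untested is made for them only; others in the source may bear on it.

Measured in a functional assay (L1210 cells) for inhibition, with Mus musculus as the target; a lower number here means a stronger inhibitor, a higher number a weaker inhibitor:
- Compound 1 `C#CCN(Cc1ccc2nc(C)nc(O)c2c1)c1ccc(C(=O)N[C@@H](CCC(=O)O)C(=O)N2CCCC2C(=O)O)cc1`: 3100 nM
- Compound 2 `C#CCN(Cc1ccc2nc(C)nc(O)c2c1)c1ccc(C(=O)N[C@@H](CCC(=O)O)C(=O)N(C)[C@@H](CCC(=O)O)C(=O)O)cc1`: 240 nM
- Compound 3 `C#CCN(Cc1ccc2nc(C)nc(O)c2c1)c1ccc(C(=O)N[C@@H](CC(C)(C)C(=O)O)C(=O)N[C@@H](CCC(=O)O)C(=O)O)cc1`: 1400 nM

Compound 2 holds the lowest of these three numbers, and the nearest to it is compound 3 at 1400 nM. The next compound, compound 4 `C#CCN(Cc1ccc2nc(C)nc(O)c2c1)c1ccc(C(=O)N[C@@H](CCC(=O)O)C(=O)N(C)CC(=O)O)cc1`, has not yet been measured. It differs from compound 2 by hydrogen in place of 2-carboxyethyl on a saturated chain carbon bound to an amide-type nitrogen and a carbonyl carbon, which turns (1,3-dicarboxypropyl)(methyl)amino into (carboxymethyl)(methyl)amino.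

For the measured compounds named here, one measured step bears on this change. It is a 13-fold lower number from compound 1 to compound 2 (1.11 log units; beyond the scatter), a large step in which (1,3-dicarboxypropyl)(methyl)amino took the place of 2-carboxypyrrolidin-1-yl. Going by the values given here, that step shows how much the group now being altered can matter, although no measured compound carries the (carboxymethyl)(methyl)amino group itself. The comparison is therefore indirect. In this assay, a higher number is expected for the new compound, beyond the scatter but somewhat smaller than the measured step. The expected change is a 7.5-fold higher number from compound 2 to compound 4 (0.88 log units; beyond the scatter). For compound 4 the estimated value is 1800 nM, with an expected range of 600 nM to 5000 nM.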

Compound 4, half-maximal inhibitory concentration: 1100 nM
For compound 4 the middle estimate is 1.6-fold (0.21 log units) above the measured one, and the stated range covers the measured number.
By their numbers in this assay, from the lowest: compound 2; then compounds 4 and 3 (each within the scatter of the next); then compound 1.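

In this assay, taking away the 2-carboxyethyl group gives a 4.6-fold higher number from compound 2 to compound 4 (0.66 log units; beyond the scatter), so the 1,3-dicarboxypropyl group of compound 2 contributes to its low number. The (carboxymethyl)(methyl)amino group still improves on 2-carboxypyrrolidin-1-yl, with a 2.8-fold lower number from compound 1 to compound 4 (0.45 log units; beyond the scatter), which divides the large earlier step into a part that stands without the 2-carboxyethyl group and a part that depends on it. No measurement at hand gives a reason for either step.

The compounds shown leave open whether the terminal carboxylic acid or the chain itself accounts for the 2-carboxyethyl contribution. A plain ethyl group or a longer 3-carboxypropyl chain on the saturated chain carbon bound to an amide-type nitrogen and a carbonyl carbon would be needed to separate the two.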